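The source may report more compounds than this note shows. Statements on the series, on what has been measured and on what is new or still open speak of the compounds shown alone.

Compound 1 `CC(C)n1ncc2c(C(=O)NCc3cn(Cc4ccccc4)nn3)cccc21` gives 9170 nM in a functional assay on MCF7 cells (Homo sapiens) for inhibition, read by MTT assay, with a stated time of 72 h; on this read-out higher numbers stand for weaker inhibition and lower numbers for stronger inhibition. Compound 2 `COc1ccc(Cn2cc(CNC(=O)c3cccc4c3cnn4C(C)C)nn2)cc1` reaches only a limit of this assay, > 40000 nM, so no number is known for it; this stands as the limit of > 40000 nM in this assay, at which 1 of the 2 values shown sits. Among the compounds with values here, the single measured step, an at least 4.3-fold higher number from compound 1 to compound 2 (0.63 log units; beyond the scatter), comes from methoxy in place of hydrogen on an aromatic carbon. Compound 3 `CC(C)n1ncc2c(C(=O)NCc3cn(Cc4ccc(C(C)(C)C)cc4)nn3)cccc21` differs from compound 2 by tert-butyl in place of methoxy on an aromatic carbon. Within the data shown here, no measured step covers tert-butyl, and the one step on this position ran toward weaker inhibition, so compound 3 is expected to stay near the limit, the expected step being a number no higher from compound 2 to compound 3 (the limit leaves the size open). Compound 3 is therefore estimated at 40000 nM, between 10000 nM and 120000 nM.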

Compound 3, half-maximal inhibitory concentration: > 40000 nM
Compound 3: only a limit was reported; the forecaster's own chance of this, stated with the estimate: 55%; the middle value sits exactly at the limit.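

Compound 3 carries tert-butyl where compound 1 has hydrogen, and this gives an at least 4.3-fold higher number from compound 1 to compound 3 (0.63 log units; beyond the scatter), so a second, purely carbon group at this position also weakens inhibition beyond the scatter. Compound 2 and compound 3 both end at a limit, so the step between them cannot be read and methoxy and tert-butyl cannot be ranked. Only compound 1 keeps a measured number: the limit of > 40000 nM in this assay, at which 2 of the 3 values shown sit.

The compounds shown leave open whether fluorine, a hydroxyl or an amine on this carbon would keep a measurable value. They also leave open how far beyond the limit compound 2 and compound 3 lie.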